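This account rests on a few compounds, and the source may have more. Where it says the series, first, only, none or still open, it means among the compounds named here.

Measured in an ADME assay on BTI cells for inhibition of Amine oxidase [flavin-containing] A (Homo sapiens), read by fluorescence and Amplex Red, with a stated time of 15 min, tested at 100 uM; a higher number here means more inhibition at the concentration tested (going by the name of the read-out), a lower number less inhibition:
Compound 1 `C#CCN(C)CCCCCOc1ccc2c(c1)CCCC2=O` gives 26.1%.
Compound 2 `C#CCN(C)CCCCOc1ccc(C(C)=O)cc1` gives 28.6%.
Compound 3 `C#CCN(C)CCCCOc1ccc(C(C)=O)cc1OC` gives 21.1%.

Compound 3 has the lowest of the three numbers in this assay, but its gap to compound 1 and its gap to compound 2 are both within the scatter, so the three compounds read as alike. For the measured compounds named here, the only comparison between two measured compounds that differ in a single place is a number 7.5 percentage points lower from compound 2 to compound 3 (within the scatter), which concerns the methoxy and does not bear on the change considered next.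

Compound 4 `C#CCN(C)CCCCCOc1ccc(C(C)=O)cc1OC` differs from compound 3 by (methyl(propargyl)amino)methyl in place of methyl(propargyl)amino on a saturated chain carbon, four bonds along the chain from an oxygen on an aromatic ring. Going by the values given here, compound 1 and compound 2 are not a matched pair and no step between them is recorded; their numbers in this assay stand close to one another and to that of compound 3. Among the compounds with values here, with no matched step informing this change, no step beyond the scatter is expected, a number 1.9 percentage points higher from compound 3 to compound 4 (within the scatter). Compound 4 is therefore estimated at 23% in this assay, with a range from 11% to 36%.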

Compound 4, a percentage reported as inhibition, at one concentration (the size of the read-out at that concentration, not a potency): 39.5%
The estimate for compound 4 lay 16.5 percentage points below the measured number; measured number outside the range, above it.
By their numbers in this assay, from the lowest: compounds 3, 1 and 2 (each within the scatter of the next); then compound 4.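

Replacing methyl(propargyl)amino with (methyl(propargyl)amino)methyl on a saturated chain carbon, four bonds along the chain from an oxygen on an aromatic ring, gives in this assay a number 18.4 percentage points higher from compound 3 to compound 4 (beyond the scatter), the first single-place change shown here to pass the scatter. The methoxy change, a number 7.5 percentage points lower from compound 2 to compound 3 (within the scatter), did not, so this chain position is so far the only place in the series shown to move the read-out, and only for this one pair. Nothing measured here speaks to the reason for this step.

Going by these compounds, whether the same change gives a similar step without the methoxy remains open, as does whether 2-(methyl(propargyl)amino)ethyl, a longer chain, would raise the number further. Also open, on these data alone, is how the number would respond to an ethyl group in place of the propargyl on the amine.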